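Bromo-to-methyl swap on a second core in the series

The source may report more compounds than this note shows. Statements on the series, on what has been measured and on what is new or still open speak of the compounds shown alone.

Of the compounds shown here, three of one series have been measured. Compound 1 `COc1ccccc1/C=C(\C(=O)c1ccc(Cl)cc1)S(=O)(=O)c1ccc(C)cc1` gives 1000 nM in a functional assay on DU-145 cells (Homo sapiens) for inhibition, read by trypan blue exclusion, with a stated time of 96 h; a higher number here means a weaker inhibitor of growth, a lower number a stronger inhibitor of growth. Compound 2 `COc1ccccc1/C=C(\C(=O)c1ccc(Cl)cc1)S(=O)(=O)c1ccc(Br)cc1` gives 10000 nM in this assay. Compound 3 `CN(C)c1ccc(/C=C(\C(=O)c2ccc(Cl)cc2)S(=O)(=O)c2ccc(Br)cc2)cc1` carries a different core; in this assay compound 3 gives > 100000 nM, which is a limit of the assay and not a number. The core of compound 3 differs from that of compound 2 by 4-(dimethylamino)phenyl in place of 2-methoxyphenyl on a double-bonded chain carbon bound to a double-bonded chain carbon, and this change brought an at least 10-fold higher number from compound 2 to compound 3 (1.00 log units; beyond the scatter); the size of that step is bounded by the limit of > 100000 nM in this assay, at which 1 of the 3 values shown sits.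

The change from compound 2 to compound 1 is methyl in place of bromo on an aromatic carbon, and it made a 10-fold lower number from compound 2 to compound 1 (1.00 log units; beyond the scatter).

Compound 4 `Cc1ccc(S(=O)(=O)/C(=C/c2ccc(N(C)C)cc2)C(=O)c2ccc(Cl)cc2)cc1` is not yet measured. Going by the values given here, it differs from compound 3 by methyl in place of bromo on an aromatic carbon, which is the same change as the one between compound 2 and compound 1, at a place described in identical words. Within the compounds shown, this change occurs twice, once measured and once to be measured.

The step from compound 3 to compound 4 in this assay is expected to resemble the measured one, an at least 3.3-fold lower number from compound 3 to compound 4 (0.52 log units; beyond the scatter) being estimated beside a 10-fold lower number from compound 2 to compound 1 (1.00 log units; beyond the scatter). That expectation rests on the value of compound 1 relative to compound 2, with the caveat that the starting value of compound 3 is only a limit, so the true step may be larger or smaller. For compound 4 the estimate in this assay is 30000 nM, expected to lie between 8000 nM and 150000 nM.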

Compound 4, concentration for 50% growth inhibition: > 100000 nM
Compound 4 gave a limit, no number; the forecaster's own chance of this, stated with the estimate: 35%; at least 3.3-fold (0.52 log units) between middle value and limit.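

In this assay compound 4 gives > 100000 nM, which is a limit of the assay and not a number. Methyl in place of bromo gave a 10-fold lower number from compound 2 to compound 1 (1.00 log units; beyond the scatter) on the 2-methoxyphenyl core, but the same swap on the 4-(dimethylamino)phenyl core cannot be read, so these data neither show that the change carries from one core to the other nor show that it fails to: the limit of > 100000 nM in this assay, at which 2 of the 4 values shown sit. The one new step that can be read belongs to the other change, 4-(dimethylamino)phenyl in place of 2-methoxyphenyl, which gives an at least 100-fold higher number from compound 1 to compound 4 (2.00 log units; beyond the scatter) and runs in the same direction with methyl as with bromo: the same change on two cores in this assay, an at least 10-fold higher number (1.00 log units; beyond the scatter) from compound 2 to compound 3 and an at least 100-fold higher number (2.00 log units; beyond the scatter) from compound 1 to compound 4; the limit leaves it open whether they differ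

On these data alone, whether methyl in place of bromo changes anything on the 4-(dimethylamino)phenyl core stays open, as do the true positions of compound 3 and compound 4 beyond their limits. Also open, as far as these compounds go, is how a methoxy group or a carboxylic acid would behave in place of the methyl or bromo, and whether a primary amine in place of the dimethylamino group would give a value that can be read in this assay.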